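From dimethylamino to 4-methylpiperazin-1-yl in compound 2

The compounds below may be only part of what the source reports. "The series", "measured", "known", "first", "only" and "open" are said of these compounds alone.

In a functional assay on A549 cells (Homo sapiens) for antiproliferative activity, read by MTT assay, with a stated time of 48 h (on this read-out higher numbers stand for weaker inhibition and lower numbers for stronger inhibition), compound 1 (`CC(C)=CCC[C@]1(C)/C=C/[C@@H](OC(=O)C=C(C)C)[C@](C)(O)/C=C/C(=O)/C(CN(C)C)=C\C1`) gives 590 nM and compound 2 (`CC(C)=CCC[C@](C)(/C=C/[C@@H](OC(=O)C=C(C)C)[C@](C)(O)/C=C/C(=O)/C=C/N(C)C)CC=O`) gives 11200 nM. Compound 2 therefore holds the higher of the two numbers, meaning the weaker inhibition, and the gap between them lies beyond the scatter. Compound 3 (`CC(C)=CCC[C@](C)(/C=C/[C@@H](OC(=O)C=C(C)C)[C@](C)(O)/C=C/C(=O)/C=C/N1CCN(C)CC1)CC=O`) carries 4-methylpiperazin-1-yl in place of dimethylamino on a double-bonded chain carbon bound to a double-bonded chain carbon. Among the compounds with values here, no measured pair isolates this exchange, so the only direct anchor is compound 2 at 11200 nM. The step of a 1.2-fold lower number from compound 2 to compound 3 (0.09 log units; within the scatter) is expected to stay within the scatter in this assay, with a slight lean toward a lower number. In this assay the estimated value for compound 3 is 9000 nM, with an expected range of 3500 nM to 22000 nM.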

Compound 3, half-maximal inhibitory concentration: 2660 nM
Beside the measured number, compound 3's estimate is 3.4-fold (0.53 log units) above it, outside the stated range (below it).
By their numbers in this assay, from the lowest: compound 1; then compound 3; then compound 2.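

In this assay the exchange of dimethylamino for 4-methylpiperazin-1-yl on a double-bonded chain carbon bound to a double-bonded chain carbon gives a clear shift (a 4.2-fold lower number from compound 2 to compound 3 (0.62 log units; beyond the scatter)). Within the data shown here, this is the first direct reading at this position, and it shows that the group placed here is not silent: the ring-bearing 4-methylpiperazin-1-yl goes with stronger inhibition than the open dimethylamino. The data on hand offer nothing that explains this shift.

Going by these compounds, whether the ring alone carries the shift stays open, since a piperidine or a morpholine at this place could separate the ring from its second nitrogen and the methyl group on it. Also open, on these data alone, is whether the same exchange would read the same way on the core of compound 1.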